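Hydroxyphenyl series: moving one hydroxyl around the ring

This account rests on a few compounds, and the source may have more. Where it says the series, first, only, none or still open, it means among the compounds named here.

Measured so far:
Compound 1 `Oc1ccc(-c2cc(-c3cccc(F)c3)cc(-c3ccccc3O)n2)cc1`: in a functional assay on DU-145 cells (Homo sapiens) for inhibition (on this read-out higher numbers stand for weaker inhibition and lower numbers for stronger inhibition), compound 1 gives > 50000 nM
Compound 2 `Oc1cccc(-c2cc(-c3cccc(OC(F)(F)F)c3)cc(-c3ccccc3O)n2)c1`: compound 2 gives > 50000 nM
Compound 3 `Oc1ccc(-c2cc(-c3cccc(OC(F)(F)F)c3)cc(-c3ccccc3O)n2)cc1`: compound 3 gives > 50000 nM

Each of these three values is a limit of this assay and not a number. Compound 3 therefore stands at that limit, and nothing in the numbers separates it from the other two. The step from compound 1 to compound 3, trifluoromethoxy in place of fluoro, is a step that the two limits leave unreadable from compound 1 to compound 3. The step from compound 2 to compound 3, 4-hydroxyphenyl in place of 3-hydroxyphenyl, is a step that the two limits leave unreadable from compound 2 to compound 3. Both remain unreadable because of the limit of > 50000 nM in this assay, at which 3 of the 3 values shown sit.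

Compound 4 `Oc1ccc(-c2cc(-c3cccc(OC(F)(F)F)c3)cc(-c3cccc(O)c3)n2)cc1` differs from compound 3 by 3-hydroxyphenyl in place of 2-hydroxyphenyl on an aromatic carbon. Both measured steps bear on the same region of the core, yet neither gives a size or a direction, so no change beyond the scatter can be expected in this assay. The expected step is a step that the limit leaves unreadable from compound 3 to compound 4, with the likeliest outcome another limit. For compound 4 the estimate is 70000 nM, in the range 20000 nM to 300000 nM.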

Compound 4, half-maximal inhibitory concentration: 5670 nM
Estimate against measurement, compound 4: 12-fold (1.09 log units) above, and the stated range ends above it.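

In this assay, among these compounds, 3-hydroxyphenyl in place of 2-hydroxyphenyl gives an at least 8.8-fold lower number from compound 3 to compound 4 (0.94 log units; beyond the scatter), so the hydroxyl position on this ring can move the read-out, a change that can be read for the first time. With 4-hydroxyphenyl in place of 2-hydroxyphenyl, the comparison gives an at least 8.8-fold lower number from compound 2 to compound 4 (0.94 log units; beyond the scatter), and compound 4 is the only compound shown without the 2-hydroxyphenyl group. The steps among compound 1, compound 2 and compound 3, all of which carry that group, cannot be read because their values are limits: the limit of > 50000 nM in this assay, at which 3 of the 4 values shown sit.

As far as these compounds go, the true size of both readable steps stays open, since each starts from a limit, as does the effect of fluoro in place of trifluoromethoxy on the core of compound 4. Also open, from the compounds shown here alone, is whether an amine or a carboxylic acid in place of the hydroxyl of the 3-hydroxyphenyl group would keep the value of compound 4.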